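This account rests on a few compounds, and the source may have more. Where it says the series, first, only, none or still open, it means among the compounds named here.

Measured in a functional assay on HeLa S3 cells (Homo sapiens) for cytotoxicity, read by XTT assay, with a stated time of 3 days; a higher number here means a weaker inhibitor, a lower number a stronger inhibitor:
- compound 1 `OC[C@H]1O[C@@H](n2cc(F)c3c(-c4ccco4)ncnc32)[C@H](O)[C@@H]1O`: 8000 nM
- compound 2 `OC[C@H]1O[C@@H](n2cc(F)c3c(-c4ccc[nH]4)ncnc32)[C@H](O)[C@@H]1O`: 230 nM
- compound 3 `OC[C@H]1O[C@@H](n2cc(F)c3c(-c4c[nH]cn4)ncnc32)[C@H](O)[C@@H]1O`: 12200 nM

Compound 3 sits at the high end of these numbers, but it is not separated from every other compound. The measured steps are a 1.5-fold higher number from compound 1 to compound 3 (0.18 log units; within the scatter) and a 53-fold higher number from compound 2 to compound 3 (1.72 log units; beyond the scatter).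

The next change gives compound 4 `OC[C@H]1O[C@@H](n2cc(F)c3c(-c4ccoc4)ncnc32)[C@H](O)[C@@H]1O`: furan-3-yl in place of 1H-imidazol-4-yl on an aromatic carbon, (furan-3-yl in place of 1H-imidazol-4-yl on an aromatic carbon).

The closest guide is the furan-2-yl compound, since compound 1 gives 8000 nM. For the measured compounds named here, no measured pair moves the point of attachment on a furan, and a 35-fold lower number from compound 1 to compound 2 (1.54 log units; beyond the scatter) shows that one ring exchange can shift the number strongly, so the range must stay wide. A moderate step to a lower number is expected in this assay, estimated as a 4.1-fold lower number from compound 3 to compound 4 (0.61 log units; beyond the scatter). The expected value for compound 4 is 3000 nM, with an estimated range from 500 nM to 15000 nM.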

Compound 4, half-maximal inhibitory concentration: 170 nM
The estimate for compound 4 lay 18-fold (1.25 log units) above the measured number; measured number below the stated range.
By their numbers in this assay, from the lowest: compounds 4 and 2 (each within the scatter of the next); then compounds 1 and 3 (each within the scatter of the next).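

In this assay the change from furan-2-yl to furan-3-yl gives a 47-fold lower number from compound 1 to compound 4 (1.67 log units; beyond the scatter) and so shows that, with the same ring, the point of attachment alone can carry a large step at this position. The exchange of 1H-imidazol-4-yl for furan-3-yl gives a 72-fold lower number from compound 3 to compound 4 (1.86 log units; beyond the scatter) as a further large step, while a 1.4-fold lower number from compound 2 to compound 4 (0.13 log units; within the scatter) leaves the two compounds level, so two different rings, 1H-pyrrol-2-yl and furan-3-yl, reach the low end of this short series. Nothing in the data shown accounts for these steps.

Still open, going by these compounds, is whether this sensitivity to ring and attachment point extends to thiophen-3-yl, to a six-membered ring such as pyridin-3-yl, or to an amine on the same carbon. Also open, on these data alone, is whether a methyl group on the furan-3-yl ring would be tolerated in this assay as well.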